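A few compounds are considered here, and "the series" means these few. Any claim that something is new, unique, unknown or untested is made for them only; others in the source may bear on it.

Measured compounds in a functional assay on the whole organism (artery, strain albino) with Rattus norvegicus as the target, with a stated time of 60 min, at a dose of 10 mg/kg by the oral route; a lower number here means less inhibition, a higher number more inhibition at the dose given (going by the name of the read-out):
compound 1 `CC1=C(C(=O)Nc2ccc([N+](=O)[O-])cc2)C(c2ccc(Br)cc2)N=C(SCc2ccccc2)N1` gives 8.2%
compound 2 `CC1=C(C(=O)Nc2ccc([N+](=O)[O-])cc2)C(c2ccc(Br)cc2)N=C(SCc2ccccc2Cl)N1` gives 6.7%
compound 3 `CC1=C(C(=O)Nc2ccc([N+](=O)[O-])cc2)C(c2ccc(Br)cc2)N=C(SCc2cccc(Cl)c2)N1` gives 4.1%

Compound 3 holds the lowest of the three numbers in this assay, though the gap to compound 2 and the gap to compound 1 are both within the scatter, so no order among the three can be read from these values.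

Compound 4 `CC1=C(C(=O)Nc2ccc([N+](=O)[O-])cc2)C(c2ccc(Br)cc2)N=C(SCc2ccc(Cl)cc2)N1` is the next member. The change from compound 3 is 4-chlorophenyl in place of 3-chlorophenyl on a saturated chain carbon bound to a sulfur.

Within the data shown here, two steps bear on this change. The step of a number 2.6 percentage points lower from compound 2 to compound 3 (within the scatter) moves the chloro from one place on the benzyl ring to another, and is within the scatter. The steps of a number 1.5 percentage points lower from compound 1 to compound 2 (within the scatter) and a number 4.1 percentage points lower from compound 1 to compound 3 (within the scatter) add a chloro to the benzyl ring at either place, and both are within the scatter as well. Among the measured compounds shown here, nothing measured so far suggests that where the chloro sits on this ring shifts the inhibition beyond the scatter. The step from compound 3 to compound 4 is therefore expected to be small, a number 1.9 percentage points higher from compound 3 to compound 4 (within the scatter), with no direction beyond the scatter.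

Compound 4 is expected to give about 6% in this assay, between 0% and 14%.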

Compound 4, a percentage reported as inhibition, in the whole organism at one dose (the size of the read-out at that dose, not a potency): 10.8%
The estimate for compound 4 lay 4.8 percentage points below the measured number; measured number inside the range.
By their numbers in this assay, from the lowest: compounds 3, 2, 1 and 4 (each within the scatter of the next).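

In this assay the change to 4-chlorophenyl in place of 3-chlorophenyl on a saturated chain carbon bound to a sulfur is a number 6.7 percentage points higher from compound 3 to compound 4 (within the scatter) and the change to 4-chlorophenyl in place of 2-chlorophenyl is a number 4.1 percentage points higher from compound 2 to compound 4 (within the scatter) so all three chlorophenyl groups now shown at this place lie within the scatter of one another. Chloro in place of hydrogen on the aromatic ring to give the 4-chlorobenzyl group is a number 2.6 percentage points higher from compound 1 to compound 4 (within the scatter) and so the benzyl group without chloro is not separated from any of its three chloro counterparts either. No measurement available here accounts for the values at this position.

Still open, as far as these compounds go, is whether any group at this place can move the inhibition beyond the scatter, for example a methoxy group, an amine or a carboxylic acid on the benzyl ring, or a longer chain between the sulfur and the ring. Also open, from the compounds shown here alone, is whether changes elsewhere on the shared core would give a step beyond the scatter in this assay as all four compounds here differ only on the benzyl ring.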